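Working notes: the step from compound 3 to compound 4

The source may report more compounds than this note shows. Statements on the series, on what has been measured and on what is new or still open speak of the compounds shown alone.

- compound 1 `CCC/N=C1\S/C(=C\c2ccc(C(=O)OC)cc2)C(=O)N1c1ccccc1C` gives > 3 h (a limit)
- compound 2 `CCC/N=C1\S/C(=C\c2ccc(C(=O)OCCO)cc2)C(=O)N1c1ccccc1C` gives > 3 h (a limit)
- compound 3 `CCC/N=C1\S/C(=C\c2ccc(C(=O)OCC(O)CO)cc2)C(=O)N1c1ccccc1O` gives > 3 h (a limit)

In an ADME assay on a cell-free system (plasma, Homo sapiens) for metabolic stability, at 37 degrees C (a lower number here means that the compound disappears faster, a higher number that the compound lasts longer), compound 3 stands at > 3 h (a limit, not a number). The series as a whole offers no more (the limit of > 3 h in this assay, at which 3 of the 3 values shown sit). Compound 4 `CCC/N=C1\S/C(=C\c2ccc(CCC(=O)OC)cc2)C(=O)N1c1ccccc1O` differs from compound 3 by 2-(methoxycarbonyl)ethyl in place of (2,3-dihydroxypropoxy)carbonyl on an aromatic carbon. Among the measured compounds shown here, the only measured step (a step that the two limits leave unreadable from compound 1 to compound 2) gives no size to carry over. No step beyond the scatter is therefore expected in this assay, and no direction can be read. The expected step is an estimate only (a step that the limit leaves unreadable from compound 3 to compound 4). Another limit reading is likely. Compound 4 is expected at 4 h (estimated range 1.5 h to 12 h).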

Compound 4, half-life: > 3 h
Compound 4 gave a limit, no number; the forecaster's own chance of this, stated with the estimate: 70%; the middle value does not contradict the limit.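

In this assay compound 3 gives > 3 h, a limit. Among the compounds shown here, compound 4 gives > 3 h, also a limit, so no step between these two compounds can be read. The compounds shown leave open the actual half-life of each and whether any group change alters it.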